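A few compounds are considered here, and "the series" means these few. Any claim that something is new, unique, unknown or untested is made for them only; others in the source may bear on it.

Compound 3 `CC(C(=O)NCc1ccc(C(C)(C)C)cc1N1CCN(c2ccccc2)CC1)c1ccc(NS(C)(=O)=O)c(F)c1` holds the lowest number of the three in an assay on cells for antagonist activity at transient receptor potential cation channel subfamily V member 1 (Homo sapiens), read by FLIPR and calcium flux, with a stated time of 6 min (a higher number here means a weaker inhibitor, a lower number a stronger inhibitor), giving 0.8 nM. Compound 1 `CCCCN(C)c1cc(C(C)(C)C)ccc1CNC(=O)C(C)c1ccc(NS(C)(=O)=O)c(F)c1` gives 1 nM and compound 2 `CC(C(=O)NCc1ccc(C(C)(C)C)cc1N1CCCC1)c1ccc(NS(C)(=O)=O)c(F)c1` gives 8.1 nM; the gap a 1.3-fold lower number from compound 1 to compound 3 (0.10 log units; within the scatter) lies within the scatter, whereas a 10-fold lower number from compound 2 to compound 3 (1.01 log units; beyond the scatter) is large, as is an 8.1-fold higher number from compound 1 to compound 2 (0.91 log units; beyond the scatter). Compound 4 `CCCCOc1cc(C(C)(C)C)ccc1CNC(=O)C(C)c1ccc(NS(C)(=O)=O)c(F)c1` carries butoxy in place of 4-phenylpiperazin-1-yl on an aromatic carbon. The closest guide is compound 1, whose acyclic substituent on the aromatic carbon gave 1 nM, a number indistinguishable from that of compound 3. Going by the values given here, no measured step installs butoxy, so the bearing of the two large steps on compound 4 is unknown. Compound 4 is therefore expected to show a 2.5-fold higher number from compound 3 to compound 4 (0.40 log units; beyond the scatter), a small step at most, with an estimated 2 nM and a range of 0.6 nM to 7 nM.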

Compound 4, inhibition constant: 1.4 nM
Compound 4: middle estimate off by 1.4-fold (0.15 log units), on the high side; measured number inside the range.
By their numbers in this assay, from the lowest: compounds 3, 1 and 4 (each within the scatter of the next); then compound 2.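

At this aromatic carbon a ring nitrogen-linked group is not required in this assay: butoxy, with no ring, gives a 1.4-fold higher number from compound 1 to compound 4 (0.15 log units; within the scatter) and a 1.8-fold higher number from compound 3 to compound 4 (0.24 log units; within the scatter), so neither the change of linking atom nor the loss of both rings of 4-phenylpiperazin-1-yl can be read as a shift. Only pyrrolidin-1-yl stands apart, with a 5.8-fold lower number from compound 2 to compound 4 (0.76 log units; beyond the scatter). No measurement in hand accounts for these differences.

Open, from the compounds shown here alone, is whether methoxy or a longer chain such as hexyloxy holds this level. Phenoxy, which keeps the oxygen and restores an aromatic ring, is equally open.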